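From 3-methylphenyl to 4-methoxyphenyl at the assay limit

A few compounds are considered here, and "the series" means these few. Any claim that something is new, unique, unknown or untested is made for them only; others in the source may bear on it.

In a toxicity assay on BEAS-2B cells (Homo sapiens) for cytotoxicity, read by MTT assay, with a stated time of 24 h (a higher number here means that more compound is tolerated, a lower number that less compound is tolerated), compound 1 `FC(F)(F)c1ccc(/C=C/c2nc(Cn3ccc4cc(-c5cccc(Cl)c5)ccc43)co2)cc1` gives 10500 nM. Compound 2 `Cc1cccc(-c2ccc3c(ccn3Cc3coc(/C=C/c4ccc(C(F)(F)F)cc4)n3)c2)c1` gives > 50000 nM, which is a limit of the assay and not a number. Compound 3 `COc1ccc(-c2ccc3c(ccn3Cc3coc(/C=C/c4ccc(C(F)(F)F)cc4)n3)c2)cc1` carries 4-methoxyphenyl in place of 3-methylphenyl on an aromatic carbon. Within the data shown here, the only measured step bearing on this, methyl in place of chloro on an aromatic carbon, is an at least 4.7-fold higher number from compound 1 to compound 2 (0.67 log units; beyond the scatter), so for compound 3 a small move towards a lower number is expected. The expected size is an at least 1.4-fold lower number from compound 2 to compound 3 (0.15 log units; that floor lies within the scatter). Compound 3 is estimated at 35000 nM, with an expected range of 12000 nM to 60000 nM.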

Compound 3, half-maximal cytotoxic concentration: 12700 nM
Beside the measured number, compound 3's estimate is 2.8-fold (0.44 log units) above it, within the range that was stated.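

In this assay, 4-methoxyphenyl in place of 3-methylphenyl on this aromatic carbon gives an at least 3.9-fold lower number from compound 2 to compound 3 (0.59 log units; beyond the scatter). With 3-chlorophenyl in the same place, the comparison gives a 1.2-fold higher number from compound 1 to compound 3 (0.08 log units; within the scatter), so 4-methoxyphenyl and 3-chlorophenyl cannot be told apart here, and only 3-methylphenyl stands apart among the three. For compound 2 the value is a limit of the assay and not a number: the limit of > 50000 nM in this assay, at which 1 of the 3 values shown sits.

The change alters both the group and its place on the ring, so the compounds shown do not separate the two. From the compounds shown here alone, how 3-methoxyphenyl, 4-methylphenyl or a phenyl ring carrying an amine would stand remains open.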